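The source may hold more compounds than are shown below. What is called first, only, known or untested is meant among the compounds shown, and "the series" means these compounds.

In an in vitro ADME assay on microsomes from liver (Homo sapiens) for metabolic stability (on this read-out lower numbers stand for slow clearance and higher numbers for fast clearance), compound 1 `CC[C@H](C)[C@@H]1C(=O)N[C@H](C2Cc3ccccc3C2)C(=O)N1[C@@H](C(=O)N(C)C)c1ccc(C)nc1C` gives 7 mL.min-1.g-1. For the measured compounds named here, the only other measured compound, compound 2 `CCC(CC)[C@@H]1C(=O)N[C@H](C2Cc3ccccc3C2)C(=O)N1[C@@H](C(=O)N(C)C)c1ccc(C)nc1`, gives 11 mL.min-1.g-1. These two numbers lie within the scatter of each other, so compound 1 cannot be separated from compound 2 on this evidence. Compound 3 `CC[C@H](C)[C@@H]1C(=O)N[C@H](C2Cc3ccccc3C2)C(=O)N1[C@@H](C(=O)N(C)C)c1cc(C)cnc1C` keeps the core of compound 1 and alters one group: 2,5-dimethylpyridin-3-yl in place of 2,6-dimethylpyridin-3-yl on a saturated chain carbon bound to an amide-type nitrogen in a ring and a carbonyl carbon. The 2,5-dimethylpyridin-3-yl stands in place of the 2,6-dimethylpyridin-3-yl on a saturated chain carbon bound to an amide-type nitrogen in a ring and a carbonyl carbon. Going by the values given here, no measured pair isolates this kind of change, so the data give no direct guide to its size or direction. No step beyond the scatter is therefore expected in this assay, and the estimate stays close to compound 1 at 7 mL.min-1.g-1. The expected change is small, with an estimated 1.3-fold higher number from compound 1 to compound 3 (0.11 log units; within the scatter). For compound 3 the estimated value is 9 mL.min-1.g-1, with an expected range of 4 mL.min-1.g-1 to 20 mL.min-1.g-1.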

Compound 3, intrinsic clearance in microsomes: 5 mL.min-1.g-1
Estimate against measurement, compound 3: 1.8-fold (0.26 log units) above, and the stated range covers the measured number.
By their numbers in this assay, from the lowest: compounds 3, 1 and 2 (each within the scatter of the next, the first and the last beyond it).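

In this assay, 2,5-dimethylpyridin-3-yl in place of 2,6-dimethylpyridin-3-yl on a saturated chain carbon bound to an amide-type nitrogen in a ring and a carbonyl carbon gives a 1.4-fold lower number from compound 1 to compound 3 (0.15 log units; within the scatter). For the compounds shown here, this is the first pair that isolates a single change at this position, and it shows that this rearrangement of the same atoms cannot be told apart from the original group on this read-out. Nothing available explains this result.

Going by these compounds, whether a plain phenyl ring, or a pyridine carrying a methoxy group or a trifluoromethyl group, would move the number beyond the scatter remains open. Going by these compounds alone, this single pair also cannot show whether the same exchange would behave alike with another chain in place of the one shared by compound 1 and compound 3.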